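Swapping hydroxy for cyano: a repeated step in two cores

The source may hold more compounds than are shown below. What is called first, only, known or untested is meant among the compounds shown, and "the series" means these compounds.

Measured compounds:
compound 1, `O=C(/C=C/c1cccc(O)c1)c1cc(O)c(O)c([N+](=O)[O-])c1`, giving 43900 nM in an assay on isolated protein for inhibition of Amine oxidase [flavin-containing] A (Homo sapiens), read by fluorescence; on this read-out lower numbers stand for stronger inhibition and higher numbers for weaker inhibition
compound 2, `N#Cc1cccc(/C=C/C(=O)c2cc(O)c(O)c([N+](=O)[O-])c2)c1`, giving 58900 nM in this assay
compound 3, `CC(=O)N1N=C(c2cc(O)c(O)c([N+](=O)[O-])c2)CC1c1cccc(O)c1`, giving 87000 nM in this assay

Compound 1 and compound 2 share one core and differ in a single spot: cyano in place of hydroxy on an aromatic carbon. The step of a 1.3-fold higher number from compound 1 to compound 2 (0.13 log units; within the scatter) is small and within the scatter, so the two values cannot be told apart with confidence.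

Compound 3 is built on a different core; the difference between the two cores is not broken down here. Its value and the values of compound 1 and compound 2 all lie within the scatter of one another, so none of the three can be called stronger or weaker on this evidence.

Compound 4, `CC(=O)N1N=C(c2cc(O)c(O)c([N+](=O)[O-])c2)CC1c1cccc(C#N)c1`, has not been measured. It stands to compound 3 as compound 2 stands to compound 1: cyano in place of hydroxy on an aromatic carbon. The surroundings of the change are described in the same words for both pairs, so this is the same change made on a second core.

Because a 1.3-fold higher number from compound 1 to compound 2 (0.13 log units; within the scatter) barely moved the number, compound 4 is expected to land near compound 3, with a step of about a 1.3-fold higher number from compound 3 to compound 4 (0.10 log units; within the scatter) in this assay. The estimate for compound 4 is 110000 nM, likely falling between 40000 nM and 300000 nM. This rests on one matched pair only, so the uncertainty is wide, and a reading that is only a limit cannot be ruled out.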

Compound 4, half-maximal inhibitory concentration: 70600 nM
Estimate against measurement, compound 4: 1.6-fold (0.19 log units) above; the range from low to high includes it.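

On the second core, going from 3-hydroxyphenyl to 3-cyanophenyl gives a 1.2-fold lower number from compound 3 to compound 4 (0.09 log units; within the scatter) in this assay, so here too the two values cannot be told apart with confidence. Set side by side, the steps on the two cores do not differ by more than repeated measurements of this kind would be expected to: the same change on two cores in this assay, a 1.3-fold higher number (0.13 log units; within the scatter) from compound 1 to compound 2 and a 1.2-fold lower number (0.09 log units; within the scatter) from compound 3 to compound 4, 1.7-fold (0.22 log units) apart, within the scatter of two such steps. In this small series, then, the change behaves alike on both cores in that neither step can be distinguished from the scatter, but this does not show that hydroxy and cyano are truly equivalent here, and two matched pairs cannot say whether the same would hold on any further core.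

The compounds shown leave open whether a different group in this place, such as an amine, a carboxylic acid or a longer chain, would shift the number beyond the scatter, since only hydroxy and cyano appear there. On these data alone, it also remains open whether replacing the nitro group or either of the two hydroxy groups on the other side of the molecule, all of which are present in all four compounds, would do so.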